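Furan Ester in Place of Benzyl: Three Low Readings So Far

The source may hold more compounds than are shown below. What is called first, only, known or untested is meant among the compounds shown, and "the series" means these compounds.

In an ADME assay on PC-3 cells (Homo sapiens) for cytotoxicity, read by WST assay, tested at 100 uM (on this read-out lower numbers stand for less inhibition and higher numbers for more inhibition at the one concentration tested (going by the name of the read-out)), compound 1, `O=C(Nc1cccc([N+](=O)[O-])c1)C1CCCN(C(=O)c2cc(C(F)(F)F)cc(C(F)(F)F)c2)C1`, gives 9%. Compound 2, `O=C(Nc1cccc(-c2cnco2)c1)C1CCCN(C(=O)c2cc(C(F)(F)F)cc(C(F)(F)F)c2)C1`, gives 9%. Compound 3, `O=C(Nc1cccc(Cc2ccccc2)c1)C1CCCN(C(=O)c2cc(C(F)(F)F)cc(C(F)(F)F)c2)C1`, gives 0%.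

Compound 3 stands level with its two neighbours: a number 9 percentage points lower from compound 1 to compound 3 (within the scatter) and a number 9 percentage points lower from compound 2 to compound 3 (within the scatter) both fall within the scatter, as does no change at the digits printed from compound 1 to compound 2 (within the scatter). Compound 4, `COC(=O)c1cc(-c2cccc(NC(=O)C3CCCN(C(=O)c4cc(C(F)(F)F)cc(C(F)(F)F)c4)C3)c2)co1`, differs from compound 3 at the same position that all three measured steps vary: 5-(methoxycarbonyl)furan-3-yl in place of benzyl on an aromatic carbon. For the measured compounds named here, no measured step brings in a 5-(methoxycarbonyl)furan-3-yl, so the change itself is untested. Each measured change at this position stayed within the scatter, so compound 4 is expected to stay near the floor too, with the expected step of a number 5 percentage points higher from compound 3 to compound 4 (within the scatter). The estimate for compound 4 in this assay is 5%, expected between 0% and 20%.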

Compound 4, a percentage reported as inhibition, at one concentration (the size of the read-out at that concentration, not a potency): 0%
Compound 4: middle estimate off by 5 percentage points, on the high side, within the range that was stated.
By their numbers in this assay, from the lowest: compounds 3, 4, 1 and 2 (each within the scatter of the next).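

In this assay the position also accepts 5-(methoxycarbonyl)furan-3-yl, which carries hydrogen-bond acceptors where benzyl has none, and the step shows no change at the digits printed from compound 3 to compound 4 (within the scatter) for this exchange. Against the other two groups, the readings show a number 9 percentage points lower from compound 2 to compound 4 (within the scatter) and a number 9 percentage points lower from compound 1 to compound 4 (within the scatter), so all four groups remain within the scatter of one another. Nothing available explains this flat picture.

The compounds shown leave open whether any group at this position would give a reading beyond the scatter, such as an amine or a carboxylic acid in place of the methyl ester. They also leave open whether replacing a trifluoromethyl group on the shared core with a nitrile would do so.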